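Acetylation of the Last Free Hydroxy Group

A few compounds are considered here, and "the series" means these few. Any claim that something is new, unique, unknown or untested is made for them only; others in the source may bear on it.

Compound 1, `C=C1CC[C@@H]2[C@](C)(CO[Si](C(C)C)(C(C)C)C(C)C)[C@H](O)CC[C@@]2(C)[C@@H]1C/C=C1/C(=O)OC[C@H]1O`: 3.01 uM
Compound 2, `C=C1CC[C@@H]2[C@](C)(COC(C)=O)[C@H](O)CC[C@@]2(C)[C@@H]1C/C=C1/C(=O)OC[C@H]1OC(C)=O`: 19.8 uM
Compound 3, `C=C1CC[C@@H]2[C@](C)(CO[Si](C)(C)C(C)(C)C)[C@H](OC(C)=O)CC[C@@]2(C)[C@@H]1C/C=C1/C(=O)OC[C@H]1O`: 9.62 uM

Of the compounds shown here, three on a shared core have been measured in a functional assay on Lu1 cells (Homo sapiens) for cytotoxicity, read by sulforhodamine B assay; on this read-out higher numbers stand for an effect only at larger amounts of compound and lower numbers for an effect already at smaller amounts. Compound 2 gives the highest number of the three, 19.8 uM. Compound 3 stands nearest to it with 9.62 uM, a gap that lies beyond the usual scatter, and compound 1 stands furthest away with 3.01 uM, also beyond the scatter. Among these three, the numbers rise as acetyl replaces hydrogen on the oxygens of the core, though compound 1 and compound 3 also differ from compound 2 in the silyl groups, so no pair differs in only one place.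

Compound 4, `C=C1CC[C@@H]2[C@](C)(COC(C)=O)[C@H](OC(C)=O)CC[C@@]2(C)[C@@H]1C/C=C1/C(=O)OC[C@H]1OC(C)=O`, is the next member. It differs from compound 2 in one way: acetyl in place of hydrogen on an oxygen on a saturated carbon. For the measured compounds named here, no measured pair shows this change alone, so the size of the step has to be expected rather than read off. Given that compound 2 already gives 19.8 uM and that every added acetyl among the measured compounds has gone with a higher number, a modest upward step, near the edge of the scatter, is expected in this assay, a 1.5-fold higher number from compound 2 to compound 4 (0.18 log units; within the scatter). Compound 4 is therefore estimated at 30 uM, with a range from 12 uM to 75 uM.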

Compound 4, concentration for half-maximal effect: 12.4 uM
Compound 4: middle estimate off by 2.4-fold (0.38 log units), on the high side; the range from low to high includes it.
By their numbers in this assay, from the lowest: compound 1; then compounds 3, 4 and 2 (each within the scatter of the next, the first and the last beyond it).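

For the compounds shown here, the swap of hydrogen for acetyl on an oxygen on a saturated carbon, hydroxy to acetoxy, is the first change that can be read alone, and in this assay it amounts to a 1.6-fold lower number from compound 2 to compound 4 (0.20 log units; within the scatter). Going by these compounds alone, compound 2 and compound 4 therefore stand level within the scatter, so the rise that seemed to go with added acetyl among the earlier compounds, which also differed in their silyl groups, does not appear when this one hydroxy group is acetylated, and compound 4 goes against that pattern. Nothing available speaks to why this step stays so small.

What the compounds shown leave open is whether this oxygen would tolerate other groups equally well, such as a longer chain like butanoyl, a methyl ether or a benzoyl ester, or an amine in place of the hydroxy group. Also open, on these data alone, is whether the same acetyl swap would read alike on compounds that carry a triisopropylsilyl or tert-butyldimethylsilyl group instead of the acetyl groups that compound 2 and compound 4 share.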